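This account rests on a few compounds, and the source may have more. Where it says the series, first, only, none or still open, it means among the compounds named here.

Working notes on the series. In an assay on COS-7 cells for inhibition of patatin-like phospholipase domain-containing protein 2 (Mus musculus) (on this read-out higher numbers stand for weaker inhibition and lower numbers for stronger inhibition), compound 1 `CCOC(=O)c1cccc(-c2ccc(N(C)C)cc2)c1` gives 40000 nM, the lowest of the numbers obtained so far. Compound 3 `CCOC(=O)c1cccc(-c2ccc(C(C)=O)cc2)c1` gives 200000 nM in this assay, and the step of a 5.0-fold higher number from compound 1 to compound 3 (0.70 log units; beyond the scatter) is beyond the scatter. Compound 2 `CCOC(=O)c1cccc(-c2ccc(CN3CCCC3)cc2)c1` returns only a limit of the assay, > 200000 nM, so that for the step of an at least 5.0-fold higher number from compound 1 to compound 2 (0.69 log units; beyond the scatter) a lower bound is all that can be read.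

Compound 4 `CN(C)C(=O)Nc1cccc(-c2ccc(N(C)C)cc2)c1` has not yet been measured in this assay. It differs from compound 1 by (dimethylcarbamoyl)amino in place of ethoxycarbonyl on an aromatic carbon. Every measured step in the series touches the dimethylamino side of the core and leaves the ethoxycarbonyl unchanged, so none of them bears directly on this change; they show only that the series sits in a weak range, with compound 1 at the strong end of it and one value at the limit (the limit of > 200000 nM in this assay, at which 1 of the 3 values shown sits).

Within the data shown here, with no measured step at this position, the expectation for compound 4 in this assay is an estimate of 60000 nM, within 15000 nM to 200000 nM. The step of a 1.5-fold higher number from compound 1 to compound 4 (0.18 log units; within the scatter) is therefore expected to lie near the scatter, in no firm direction.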

Compound 4, half-maximal inhibitory concentration: < 5000 nM
Compound 4: only a limit was reported; the forecaster's own chance of this, stated with the estimate: 25%; middle value at least 12-fold (1.07 log units) away from the limit.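

In this assay, the ethoxycarbonyl position is now shown to respond to change, with (dimethylcarbamoyl)amino in place of ethoxycarbonyl and the dimethylamino group kept giving an at least 8.0-fold lower number from compound 1 to compound 4 (0.90 log units; beyond the scatter). This is the only step shown that runs toward stronger inhibition from the dimethylamino compound, since the two changes on the dimethylamino side both gave higher numbers. Compound 4 is reported only as a limit, so the step is a lower bound and its full size cannot be read: the limit of < 5000 nM in this assay, at which 1 of the 4 values shown sits.

The swap alters the linking atoms, the carbonyl environment and the amide hydrogen together, so the compounds shown do not separate which of these goes with the stronger inhibition. Open too, from the compounds shown here alone, is how a carboxylic acid, a simple amine or a longer urea chain would read at this place, and whether acetyl or (pyrrolidin-1-yl)methyl in place of dimethylamino would give the same direction alongside (dimethylcarbamoyl)amino.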